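A few compounds are considered here, and "the series" means these few. Any claim that something is new, unique, unknown or untested is made for them only; others in the source may bear on it.

In a functional assay on MDA-MB-435 cells (Homo sapiens) for cytotoxicity, read by sulforhodamine B assay, with a stated time of 48 h (a higher number here means a weaker inhibitor of growth, a lower number a stronger inhibitor of growth), the three measured compounds share a fused bicyclic core carrying a chloro group, and differ in the substitution of that core and in the arrangement of the benzylic side chain.

Compound 1 `ClCc1ccccc1Cn1cnc2c(Cl)nc(Cl)nc21` gives 3230 nM. Compound 2 `ClCc1ccccc1Cn1cnc2c(Cl)ncnc21` gives 9550 nM. The difference between them is chloro in place of hydrogen on an aromatic carbon, and it produces a 3.0-fold lower number from compound 2 to compound 1 (0.47 log units; beyond the scatter).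

Compound 3 `ClCc1cccc(Cn2cnc3ncnc(Cl)c32)c1` gives 12900 nM. Compound 3 and compound 2 are built from the same atoms joined differently; the difference between these two cores is not broken down here. Their values lie within the scatter of one another, so nothing is said here about which of the two is the stronger inhibitor of growth. Against compound 1, compound 3 shows the higher number of the two.

Compound 4 `ClCc1cccc(Cn2cnc3nc(Cl)nc(Cl)c32)c1` has not yet been measured in this assay. It differs from compound 3 by chloro in place of hydrogen on an aromatic carbon, which is the same change, at the same described place, as that from compound 2 to compound 1. Because that earlier change gave a 3.0-fold lower number from compound 2 to compound 1 (0.47 log units; beyond the scatter), a step of similar size is expected from compound 3 to compound 4, namely a 3.0-fold lower number from compound 3 to compound 4 (0.48 log units; beyond the scatter). On that basis compound 4 is estimated at 4300 nM, with a likely range from 2000 nM to 9500 nM.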

Compound 4, concentration for total growth inhibition: 2810 nM
The estimate for compound 4 lay 1.5-fold (0.18 log units) above the measured number, within the range that was stated.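

In this assay, chloro in place of hydrogen on an aromatic carbon, at a place between two ring nitrogen atoms, gives a 4.6-fold lower number from compound 3 to compound 4 (0.66 log units; beyond the scatter), and the two cases of this change can be set side by side: the same change on two cores in this assay, a 3.0-fold lower number (0.47 log units; beyond the scatter) from compound 2 to compound 1 and a 4.6-fold lower number (0.66 log units; beyond the scatter) from compound 3 to compound 4, 1.6-fold (0.19 log units) apart, within the scatter of two such steps The change therefore carried over from the core of compound 2 to the core of compound 3: the number fell in both cases, and the two steps cannot be told apart in size, so neither core can be said to respond more strongly. Among the compounds shown here, this rests on only two pairs, however, and it shows neither that the step would hold on a core outside these four compounds nor why the added chloro lowers the number.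

The compounds shown leave open whether another group at the same place, such as an amine, a methoxy group or a methyl group, would lower the number as chloro does, or would leave it unchanged or raise it. They also leave open how the result would change if the chlorine of the side chain gave way to a hydroxyl group or an amine, on either arrangement of that chain.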